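Chloro step on the fused core, nitro-benzyl versus fluoro-methylphenyl

The source may report more compounds than this note shows. Statements on the series, on what has been measured and on what is new or still open speak of the compounds shown alone.

Measured compounds:
compound 1 `Cc1nc2ccccc2c(-c2ccccc2)c1C(=O)OCc1cn(Cc2ccc([N+](=O)[O-])cc2)nn1` 42000 nM
compound 2 `Cc1nc2ccc(Cl)cc2c(-c2ccccc2)c1C(=O)OCc1cn(Cc2ccc([N+](=O)[O-])cc2)nn1` 75000 nM
compound 3 `Cc1ccc(-n2cc(COC(=O)c3c(C)nc4ccccc4c3-c3ccccc3)nn2)cc1F` 36000 nM

All three were run in an ADME assay on J774.A1 cells (Mus musculus) for cytotoxicity, read by MTT assay, with a stated time of 48 h; a higher number here means that more compound is tolerated, a lower number that less compound is tolerated. Compound 1 and compound 2 share a core; the change between them is chloro in place of hydrogen on an aromatic carbon and it gave a 1.8-fold higher number from compound 1 to compound 2 (0.25 log units; within the scatter). Compound 3 carries a different group on the triazole nitrogen; the difference to compound 1 is 3-fluoro-4-methylphenyl in place of 4-nitrobenzyl on an aromatic nitrogen and the step was a 1.2-fold lower number from compound 1 to compound 3 (0.07 log units; within the scatter). The values of compound 2 and compound 3 differ beyond the scatter, but no single change links them, so only the two numbers themselves can be compared.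

Compound 4 `Cc1ccc(-n2cc(COC(=O)c3c(C)nc4ccc(Cl)cc4c3-c3ccccc3)nn2)cc1F` has not been measured. It differs from compound 3 by chloro in place of hydrogen on an aromatic carbon, the same change as from compound 1 to compound 2: the place is described in identical words for both pairs. With only one earlier occurrence of this change, and that one within the scatter, the expectation rests on that step alone. The step from compound 3 to compound 4 is expected to be about a 1.7-fold higher number from compound 3 to compound 4 (0.22 log units; within the scatter), matching the earlier one. Compound 4 is therefore estimated at 60000 nM, with a likely range from 30000 nM to 120000 nM.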

Compound 4, half-maximal cytotoxic concentration: 34000 nM
Beside the measured number, compound 4's estimate is 1.8-fold (0.25 log units) above it; measured number inside the range.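

In this assay, the chloro change gave a 1.1-fold lower number from compound 3 to compound 4 (0.02 log units; within the scatter), and this step does not differ from its earlier occurrence on the other core: the same change on two cores in this assay, a 1.8-fold higher number (0.25 log units; within the scatter) from compound 1 to compound 2 and a 1.1-fold lower number (0.02 log units; within the scatter) from compound 3 to compound 4, 1.9-fold (0.28 log units) apart, within the scatter of two such steps. On the chloro-bearing core, 3-fluoro-4-methylphenyl in place of 4-nitrobenzyl gave a 2.2-fold lower number from compound 2 to compound 4 (0.34 log units; beyond the scatter), and this modest step also agrees with its earlier occurrence: the same change on two cores in this assay, a 1.2-fold lower number (0.07 log units; within the scatter) from compound 1 to compound 3 and a 2.2-fold lower number (0.34 log units; beyond the scatter) from compound 2 to compound 4, 1.9-fold (0.28 log units) apart, within the scatter of two such steps. Across these four compounds, neither change shows a measurable dependence on the group present elsewhere in the molecule, but with two occurrences of each change, this does not show that either step would carry over to further cores or that the two cores respond identically.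

Going by these compounds, what remains open is whether a group other than chloro on that aromatic carbon, such as methoxy or an amine, would give a step beyond the scatter. Also open, on these data alone, is how a longer chain or a carboxylic acid on the aromatic nitrogen substituent would read in this assay.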